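This account rests on a few compounds, and the source may have more. Where it says the series, first, only, none or still open, it means among the compounds named here.

Two agonists of the same receptor open the comparison. Compound 1 `CCc1nc2c(C(=O)NCC3CCN(CC(O)CN4CCN(S(C)(=O)=O)CC4)CC3)cccc2[nH]1` carries an ethyl group on its fused core; in a functional assay for agonist activity at 5-hydroxytryptamine receptor 4 (Homo sapiens), read by cAMP accumulation (a lower number here means a smaller maximal response, a higher number a larger maximal response), compound 1 gives 22%, the higher of the two values in hand. Compound 2 `CS(=O)(=O)N1CCN(CC(O)CN2CCC(NC(=O)c3cccc4[nH]cnc34)CC2)CC1` lacks that ethyl group and also joins its amide directly to the piperidine ring; in this assay compound 2 gives 7%, a value lower than that of compound 1 by a gap that lies beyond the usual scatter of such measurements. Within the data shown here, no single-change step between measured compounds exists here, so the two values can only be read side by side.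

Compound 3 `CS(=O)(=O)N1CCN(CC(O)CN2CCC(CNC(=O)c3cccc4[nH]cnc34)CC2)CC1` keeps the methylene link of compound 1 but drops the ethyl group: hydrogen in place of ethyl on an aromatic carbon. The change sits on an aromatic carbon of a five-membered aromatic ring with two nitrogen atoms, between those two ring nitrogen atoms, in a fused system of two rings. Because compound 2, which also lacks the ethyl group, gives 7%, a fall in maximal response is expected, though of uncertain size. Compound 3 is estimated to reach 12% in this assay, within 3% to 25%, an expected step of a number 10 percentage points lower from compound 1 to compound 3 (within the scatter).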

Compound 3, intrinsic activity: the largest response reached, in percent of the reference agonist's: 6%
Compound 3: middle estimate off by 6 percentage points, on the high side, and the stated range covers the measured number.
By their numbers in this assay, from the lowest: compounds 3 and 2 (each within the scatter of the next); then compound 1.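

Among these compounds, this is the first single-change step at this position, and it shows that the ethyl group on the aromatic carbon between the two ring nitrogen atoms matters for the maximal response: with hydrogen in its place, this assay gives a number 16 percentage points lower from compound 1 to compound 3 (beyond the scatter). The earlier pair could not show this, since compound 1 and compound 2 differ in more than one place, whereas here the rest of the molecule stays the same and 2-ethyl-1H-benzimidazol-4-yl simply becomes 1H-benzimidazol-4-yl. No available measurement explains why the response changes with this swap.

Going by these compounds, with only ethyl and hydrogen in view at this carbon, it remains open whether a methyl group, a longer chain such as propyl, or an amine would give a response closer to that of compound 1 or to that of compound 3. On these data alone, it also remains open whether adding an ethyl group to compound 2, with its amide joined directly to the piperidine ring, would raise the response in the same way.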